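The source may report more compounds than this note shows. Statements on the series, on what has been measured and on what is new or still open speak of the compounds shown alone.

Compound 1 `CCCCCCOc1ccc2[nH]c(-c3ccccc3)c(C3=C(Br)C(=O)NC3=O)c2c1` and compound 2 `CCCCCCOc1ccc2[nH]c(-c3ccc(OC)cc3)c(C3=C(Br)C(=O)NC3=O)c2c1` share one core and differ only in one spot: methoxy in place of hydrogen on an aromatic carbon. In a physicochemical assay for lipophilicity (a lower number here means a more polar compound, a higher number a more lipophilic compound), compound 1 gives 4.08, and compound 2 gives 4.1; the step from one to the other is a number 0.02 log units higher from compound 1 to compound 2 (within the scatter). Compound 3 `Cc1ccc2[nH]c(-c3ccccc3)c(C3=C(Br)C(=O)NC3=O)c2c1` has a different core, which differs from the core of compound 1 in this way: methyl in place of hexyloxy on an aromatic carbon. That change is matched by a number 1.20 log units lower from compound 1 to compound 3 (beyond the scatter), so in this assay compound 3 gives 2.88. Compound 4 `COc1ccc(-c2[nH]c3ccc(C)cc3c2C2=C(Br)C(=O)NC2=O)cc1` carries the same change on the core of compound 3: methoxy in place of hydrogen on an aromatic carbon. The place of the change is the same in both pairs, so the step is expected to be equally small, a number 0.02 log units higher from compound 3 to compound 4 (within the scatter), because a number 0.02 log units higher from compound 1 to compound 2 (within the scatter) stayed within the scatter. Compound 4 is therefore estimated at 2.9, most likely between 2.6 and 3.2.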

Compound 4, partition coefficient: 2.85
Compound 4: middle estimate off by 0.05 log units, on the high side; the range from low to high includes it.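

Both a number 0.03 log units lower from compound 3 to compound 4 (within the scatter) and a number 0.02 log units higher from compound 1 to compound 2 (within the scatter) stay within the scatter in this assay, so the change from phenyl to 4-methoxyphenyl shows no readable effect on either core. The other comparison agrees: a number 1.25 log units lower from compound 2 to compound 4 (beyond the scatter) is large and beyond the scatter, as is a number 1.20 log units lower from compound 1 to compound 3 (beyond the scatter) in the matching pair, so methyl in place of hexyloxy makes a clear difference with either phenyl or 4-methoxyphenyl present. Two cores cannot show that the same holds on other cores, and no measurement shown explains why the methoxy step is so small.

The compounds shown leave open whether another group in the methoxy position, such as an amine or a carboxylic acid, would also stay within the scatter. They also leave open where a butoxy chain would stand against methyl and hexyloxy.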